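Pendant phenyl substituent in the aminopyrazole ketone series

A few compounds are considered here, and "the series" means these few. Any claim that something is new, unique, unknown or untested is made for them only; others in the source may bear on it.

Three analogues sharing one core have been measured in an assay for binding affinity to dual specificity mitogen-activated protein kinase kinase 4 (Homo sapiens), read by KINOMEscan, tested at 100 nM; a lower number here means a stronger effect, a higher number a weaker effect of the compound at the concentration tested. Compound 1 `CCCS(=O)(=O)Nc1ccc(F)c(C(=O)c2n[nH]c3ncc(-c4cccc(F)c4)cc23)c1F` gives 8.2%. Compound 2 `CCCS(=O)(=O)Nc1ccc(F)c(C(=O)c2n[nH]c3ncc(-c4ccc(C)cc4)cc23)c1F` gives 5.4%. Compound 3 `CCCS(=O)(=O)Nc1ccc(F)c(C(=O)c2n[nH]c3ncc(-c4ccc(N)cc4)cc23)c1F` gives 0.1%, the smallest number of the three, though its steps from the other two, a number 8.1 percentage points lower from compound 1 to compound 3 (within the scatter) and a number 5.3 percentage points lower from compound 2 to compound 3 (within the scatter), both lie within the scatter, as does a number 2.8 percentage points lower from compound 1 to compound 2 (within the scatter). All three numbers are low, so the series already binds strongly at this concentration.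

Compound 4 `CCCS(=O)(=O)Nc1ccc(F)c(C(=O)c2n[nH]c3ncc(-c4ccc(N(C)C)cc4)cc23)c1F` is not yet measured. It differs from compound 3 at the pendant phenyl: dimethylamino in place of amino on an aromatic carbon. For the measured compounds named here, the steps that bear on it are the exchanges at this same ring, from compound 1 to compound 3 and from compound 2 to compound 3, neither of which moved the number beyond the scatter. No step beyond the scatter is therefore expected in this assay; with compound 3 near the floor of the read-out, any movement can only be upward. Compound 4 is expected to give 1.5% (range 0% to 9%), an expected step of a number 1.4 percentage points higher from compound 3 to compound 4 (within the scatter).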

Compound 4, a percentage reported as activity, at one concentration (the size of the read-out at that concentration, not a potency): 2.5%
Estimate against measurement, compound 4: 1 percentage points below, and the stated range covers the measured number.
By their numbers in this assay, from the lowest: compounds 3, 4, 2 and 1 (each within the scatter of the next).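

At the pendant phenyl, in this assay, dimethylamino in place of amino gives a number 2.4 percentage points higher from compound 3 to compound 4 (within the scatter), so a larger group with no hydrogen-bond donor still leaves the number low. The same group also stands level with the other pendant rings, with a number 2.9 percentage points lower from compound 2 to compound 4 (within the scatter) and a number 5.7 percentage points lower from compound 1 to compound 4 (within the scatter), which extends the range of groups at this position that give no step beyond the scatter. No supporting measurement bears on why these numbers fall as they do.

With all four compounds this low at a single concentration, any real differences in affinity among them remain unresolved. Also open, from the compounds shown here alone, is how this assay responds to a carboxylic acid, a morpholine or a longer chain such as diethylamino at the same place on the ring.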